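This account rests on a few compounds, and the source may have more. Where it says the series, first, only, none or still open, it means among the compounds named here.

Measured so far:
compound 1 `O=C(/C=C/c1ccc(O)c(O)c1)OCc1c(-c2ccccc2)no[n+]1[O-]`: 3780 nM
compound 2 `COc1cc(/C=C/C(=O)OCCCCCO[N+](=O)[O-])ccc1OCCCCCO[N+](=O)[O-]`: > 50000 nM

For the measured compounds named here, in a functional assay on NCI-H1792 cells (Homo sapiens) for cytotoxicity, read by resazurin assay, with a stated time of 72 h (on this read-out higher numbers stand for weaker inhibition and lower numbers for stronger inhibition), compound 1 gives 3780 nM, the only number obtained. Compound 2 gives > 50000 nM, which is a limit of the assay and not a number (the limit of > 50000 nM in this assay, at which 1 of the 2 values shown sits). Compound 3 `COc1cc(/C=C/C(=O)OCc2c(-c3ccccc3)no[n+]2[O-])ccc1O` is not yet measured. It differs from compound 1 by methyl in place of hydrogen on an oxygen on an aromatic ring. Going by the values given here, no measured pair differs in one place, so the size of this step is open; a small shift toward weaker inhibition, not clearly beyond the usual scatter, is expected. For compound 3 the estimate is 6000 nM (range 2500 nM to 15000 nM), an expected step of a 1.6-fold higher number from compound 1 to compound 3 (0.20 log units; within the scatter).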

Compound 3, half-maximal inhibitory concentration: 11100 nM
Compound 3: the middle estimate sits 1.9-fold (0.27 log units) below what was measured; the measured number falls inside the stated range.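

In this assay, the change from 3,4-dihydroxyphenyl to 4-hydroxy-3-methoxyphenyl gives a 2.9-fold higher number from compound 1 to compound 3 (0.47 log units; beyond the scatter), so a methyl on this oxygen on the aromatic ring is not neutral. For the compounds shown here, this is a modest step, but it is the first single-place change and it lies beyond the scatter. Nothing measured here explains the step.

As far as these compounds go, whether a larger group, such as ethyl or a longer chain, on this oxygen would shift the value further remains open. So does the effect of methyl on the other hydroxy, or of an amine in place of either hydroxy.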